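A few compounds are considered here, and "the series" means these few. Any claim that something is new, unique, unknown or untested is made for them only; others in the source may bear on it.

Compound 1 `CC1=C(C(=O)OCC(C)C)C(c2ccoc2)NC(=O)N1`: 326 nM
Compound 2 `CC1=C(C(=O)CC(C)C)C(c2ccoc2)NC(=O)N1`: 1010 nM

Of the compounds shown here, two have been measured in an assay on membranes from HEK293 cells for displacement of a labelled ligand from adenosine receptor A2b (Homo sapiens), read by scintillation counting, with a stated time of 30 min; a higher number here means a weaker inhibitor, a lower number a stronger inhibitor. Compound 1 `CC1=C(C(=O)OCC(C)C)C(c2ccoc2)NC(=O)N1` gives 326 nM. Going by the values given here, compound 2 `CC1=C(C(=O)CC(C)C)C(c2ccoc2)NC(=O)N1` gives 1010 nM in this assay, the higher of the two numbers, and the single step connecting them, a 3.1-fold higher number from compound 1 to compound 2 (0.49 log units; beyond the scatter), lies beyond the scatter.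

Compound 3 `CC1=C(C(=O)OC2CCCC2)C(c2ccoc2)NC(=O)N1` has not yet been measured. It differs from compound 2 in one place: cyclopentyloxy in place of isobutyl on a carbonyl carbon. This change touches the measured step in two ways. It restores the ester oxygen that compound 2 lacks, reversing the kind of change seen in a 3.1-fold higher number from compound 1 to compound 2 (0.49 log units; beyond the scatter), where removing that oxygen raised the number. Among the compounds with values here, it also replaces the isobutyl carbons with a five-membered ring, a swap for which no measured pair exists here. On these data alone, the first part points to a number near that of compound 1; the second part is unknown. The expected step is therefore a 2.9-fold lower number from compound 2 to compound 3 (0.46 log units; beyond the scatter), a lower number, with the ring part left as the main uncertainty. The estimate for compound 3 is 350 nM, within a range of 120 nM to 1000 nM.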

Compound 3, inhibition constant: 1010 nM
Beside the measured number, compound 3's estimate is 2.9-fold (0.46 log units) below it; measured number outside the range, above it.
By their numbers in this assay, from the lowest: compound 1; then compounds 2 and 3 (each within the scatter of the next).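

In this assay, restoring an oxygen on the carbonyl carbon does not by itself lower the number: cyclopentyloxy in place of isobutyl gives no change at the digits printed from compound 2 to compound 3 (within the scatter). What that oxygen carries also counts, since changing isobutyl to cyclopentyl on the oxygen gives a 3.1-fold higher number from compound 1 to compound 3 (0.49 log units; beyond the scatter), so the ester of compound 1 cannot be treated as interchangeable with any other ester at this position. No measurement shown explains why a five-membered ring on the oxygen raises the number or why compound 2 and compound 3 end up within the scatter of each other.

On these data alone, it remains open whether a methyl, an ethyl or a longer chain on the oxygen would give a number below that of compound 1, at 326 nM, or whether isobutyl is unusually well suited here. The effects of the oxygen and the ring also remain tangled, and a cyclopentyl group attached directly to the carbonyl carbon would be the missing comparison for separating them.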